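This account rests on a few compounds, and the source may have more. Where it says the series, first, only, none or still open, it means among the compounds named here.

Measured compounds:
- compound 1 `ClCc1ccc(Cn2cnc3c(Cl)ncnc32)cc1`: 9340 nM
- compound 2 `ClCc1cccc(Cn2cnc3ncnc(Cl)c32)c1`: 34700 nM

In a functional assay on RPMI-8226 cells (Homo sapiens) for cytotoxicity, read by sulforhodamine B assay, with a stated time of 48 h (on this read-out higher numbers stand for weaker inhibition of growth and lower numbers for stronger inhibition of growth), compound 1 gives 9340 nM, the lowest of the two numbers recorded. Going by the values given here, compound 2, a different arrangement of the same parts, gives 34700 nM, a higher number that lies beyond the scatter; no single-point step between the two is defined, so only the two values themselves can be compared.

Compound 3 `ClCc1ccc(Cn2cnc3c(Cl)nc(Cl)nc32)cc1` has not yet been measured. It differs from compound 1 by chloro in place of hydrogen on an aromatic carbon. Nothing in the measured pair speaks to this kind of change, so no direction can be read from the series. The expected step from compound 1 to compound 3 is therefore set small, a 1.2-fold lower number from compound 1 to compound 3 (0.10 log units; within the scatter), with no movement beyond the scatter assumed. On that basis compound 3 is estimated at 7500 nM, within a range of 2500 nM to 22000 nM.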

Compound 3, concentration for total growth inhibition: 3800 nM
The estimate for compound 3 lay 2.0-fold (0.30 log units) above the measured number; low and high end bracket the measured number.
By their numbers in this assay, from the lowest: compound 3; then compound 1; then compound 2.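

In this assay the position between two ring nitrogen atoms accepts a substituent without loss of growth inhibition: chloro in place of hydrogen gives a 2.5-fold lower number from compound 1 to compound 3 (0.39 log units; beyond the scatter) as a modest step beyond the scatter. Going by these compounds alone, this is the only change that can be read at a single place, since compound 1 and compound 2 differ in their arrangement and offered no view of this position. The gain in growth inhibition is established for this one pair only, and no measurement shown gives a reason for it.

From the compounds shown here alone, whether an amine, a methoxy group or a longer chain at this position would shift the number in the same direction stays open. Also open, going by these compounds, is whether chloro here would give a similar step on the arrangement of compound 2.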